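Replacing furan with pyridine on a hydroxylated core

A few compounds are considered here, and "the series" means these few. Any claim that something is new, unique, unknown or untested is made for them only; others in the source may bear on it.

Of the compounds shown here, three sharing one core have been measured in a functional assay on DU-145 cells (Homo sapiens) for cytotoxicity, read by CCK-8 assay; on this read-out lower numbers stand for stronger inhibition and higher numbers for weaker inhibition. Compound 1 `Oc1ccc(-c2cc(-c3ccco3)cc(-c3ccccc3O)n2)cc1` gives > 50000 nM, which is a limit of the assay and not a number. Compound 2 `Oc1cccc(-c2cc(-c3ccco3)cc(-c3cccc(O)c3)n2)c1` gives 2150 nM. Compound 3 `Oc1ccc(-c2cc(-c3ccco3)cc(-c3cccc(O)c3)n2)cc1` gives 2070 nM. Among the compounds with values here, compound 3 therefore stands level with the only other true number, and the step between them is a 1.0-fold lower number from compound 2 to compound 3 (0.02 log units; within the scatter).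

The next candidate, compound 4 `Oc1ccc(-c2cc(-c3ccccn3)cc(-c3cccc(O)c3)n2)cc1`, keeps both hydroxyphenyl groups of compound 3. It has pyridin-2-yl in place of furan-2-yl, on an aromatic carbon opposite the ring nitrogen (pyridin-2-yl in place of furan-2-yl on an aromatic carbon).

Neither measured step touches that position, since both concern the hydroxyphenyl groups. One of them is large, at an at least 24-fold lower number from compound 1 to compound 3 (1.38 log units; beyond the scatter), and this shows that a single change on this core can matter greatly in this assay. The other is a 1.0-fold lower number from compound 2 to compound 3 (0.02 log units; within the scatter), which shows that a change can also leave the number in place. Neither sets the size of a ring swap, so no step beyond the scatter is expected, though with real uncertainty in either direction. The expected change is a 1.2-fold higher number from compound 3 to compound 4 (0.08 log units; within the scatter). For compound 4 the estimated value is 2500 nM, with an expected range from 700 nM to 10000 nM.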

Compound 4, half-maximal inhibitory concentration: 1980 nM
For compound 4 the middle estimate is 1.3-fold (0.10 log units) above the measured one; the range from low to high includes it.
By their numbers in this assay, from the lowest: compounds 4, 3 and 2 (each within the scatter of the next). At a limit, above all of these: compound 1.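

Within the data shown here, this is the first step on the shared core that touches the position opposite the ring nitrogen, and in this assay pyridin-2-yl in place of furan-2-yl gives a 1.0-fold lower number from compound 3 to compound 4 (0.02 log units; within the scatter). A five-membered aromatic ring carrying an oxygen and a six-membered aromatic ring carrying a nitrogen can therefore stand in this place with no readable difference, even though the entering ring is the larger of the two. The earlier steps shown here concerned only the hydroxyphenyl groups, so this result adds that the position allows at least this one change of aromatic ring without a loss, which is a statement about this single pair and not a rule for the position.

As far as these compounds go, whether the position accepts something other than an aromatic ring, such as an amine, a carboxylic acid or a longer alkyl chain, stays open, as does whether pyridin-2-yl would give the same picture with the hydroxyphenyl groups of compound 1 or compound 2. Nothing shown here explains why the two rings give matching numbers.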